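Compound 3 to Compound 4: Tolerance on Pancreatic Cancer Cells

The compounds below may be only part of what the source reports. "The series", "measured", "known", "first", "only" and "open" are said of these compounds alone.

Three measured compounds and their values in an ADME assay on PANC-1 cells (Homo sapiens) for cytotoxicity, read by MTT assay; a lower number here means that less compound is tolerated, a higher number that more compound is tolerated:
compound 1, `Cc1nc(-c2cccnc2)sc1-c1nnc(-c2cccnc2)o1`, > 100 ug/mL, a limit of the assay
compound 2, `COc1ccccc1-c1nnc(-c2sc(-c3cccnc3)nc2C)o1`, > 100 ug/mL, a limit of the assay
compound 3, `Cc1ccccc1-c1nnc(-c2sc(-c3cccnc3)nc2C)o1`, > 100 ug/mL, a limit of the assay

Compound 3 stands at the limit where all three values sit (the limit of > 100 ug/mL in this assay, at which 3 of the 3 values shown sit). The steps a step that the two limits leave unreadable from compound 1 to compound 3, a step that the two limits leave unreadable from compound 2 to compound 3 and a step that the two limits leave unreadable from compound 1 to compound 2 therefore cannot be sized. Compound 4 is `Cc1nc(-c2cccnc2)sc1-c1nnc(-c2cccc(Cl)c2Cl)o1`, and the change is 2,3-dichlorophenyl in place of 2-methylphenyl on an aromatic carbon. Among the measured compounds shown here, the measured steps bear on it only by showing that changes at this same position have so far moved no compound off the limit. No step beyond the scatter is expected in this assay. Compound 4 is expected to give 100 ug/mL, between 50 ug/mL and 200 ug/mL. The expected step is a number no higher from compound 3 to compound 4 (the limit leaves the size open).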

Compound 4, half-maximal cytotoxic concentration: > 100 ug/mL
Compound 4 ended at the assay's limit; the forecaster's own chance of this, stated with the estimate: 80%; the middle value lies on the limit itself.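

No step from compound 1, compound 2 or compound 3 to compound 4 can be sized, because all four compounds share one limit: the limit of > 100 ug/mL in this assay, at which 4 of the 4 values shown sit.

The compounds shown leave open where any of them would actually reach its half-maximal cytotoxic concentration in this assay.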